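A few compounds are considered here, and "the series" means these few. Any claim that something is new, unique, unknown or untested is made for them only; others in the source may bear on it.

In a functional assay on MCF7 cells (Homo sapiens) for cytotoxicity, read by MTT assay, with a stated time of 48 h (on this read-out higher numbers stand for weaker inhibition and lower numbers for stronger inhibition), compound 2 `O=C(CSc1nc2ccc(NC(=O)c3ccccc3)cc2s1)NCc1ccc(Cl)cc1` gives 33700 nM, the highest of the three numbers measured. Compound 1 `O=C(CSc1nc2ccc(NC(=O)c3ccc(Cl)cc3)cc2s1)NCc1ccc(Cl)cc1` gives 29300 nM, and the step of a 1.2-fold higher number from compound 1 to compound 2 (0.06 log units; within the scatter) lies within the scatter. Compound 3 `O=C(CSc1nc2ccc(NC(=O)CCl)cc2s1)NCc1ccccc1` gives 4200 nM, a lower number than compound 2 shows. Compound 4 `COc1ccc(CNC(=O)CSc2nc3ccc(NC(=O)c4ccccc4)cc3s2)cc1` differs from compound 2 in one place: methoxy in place of chloro on an aromatic carbon. Among the measured compounds shown here, no measured step exchanges chloro for methoxy, so the only step that bears on it is a 1.2-fold higher number from compound 1 to compound 2 (0.06 log units; within the scatter), which likewise removed a chloro and stayed within the scatter. The expected step in this assay, a 1.1-fold lower number from compound 2 to compound 4 (0.05 log units; within the scatter), is therefore none beyond the scatter. Compound 4 is estimated at 30000 nM, with a range from 12000 nM to 80000 nM.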

Compound 4, half-maximal inhibitory concentration: 21200 nM
Beside the measured number, compound 4's estimate is 1.4-fold (0.15 log units) above it; measured number inside the range.
By their numbers in this assay, from the lowest: compound 3; then compounds 4, 1 and 2 (each within the scatter of the next).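

In this assay, replacing 4-chlorobenzyl with 4-methoxybenzyl gives a 1.6-fold lower number from compound 2 to compound 4 (0.20 log units; within the scatter), so at this position, methoxy, which unlike chloro counts as a hydrogen-bond acceptor, produces no step beyond the scatter. Among the compounds shown here, the only earlier step removed a chloro elsewhere in the molecule, making this the first reading at this position. Nothing available explains the size of this step. From the compounds shown here alone, whether an amine or a carboxylic acid here would also stay within the scatter remains open. Compound 3 differs from these compounds in more than one place, so its lower number cannot be tied to any single change.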